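Aryl acylsulfonamides against steryl-sulfatase: methoxy for chloro

The compounds below may be only part of what the source reports. "The series", "measured", "known", "first", "only" and "open" are said of these compounds alone.

compound 1 `O=C(NS(=O)(=O)c1ccc(Cl)cc1)N1CCN(C(=O)OCc2ccccc2)CC1` — > 100000 nM
compound 2 `CC(C)(C)OC(=O)N1CCC(C(=O)NS(=O)(=O)c2cccc(Cl)c2)CC1` — 71000 nM

For the measured compounds named here, in an assay on isolated protein for inhibition of Steryl-sulfatase (Homo sapiens) (on this read-out lower numbers stand for stronger inhibition and higher numbers for weaker inhibition), compound 2 gives 71000 nM, the only plain number in the set. For compound 1 the read-out is a limit only: the limit of > 100000 nM in this assay, at which 1 of the 2 values shown sits. Compound 3 `COc1ccc(S(=O)(=O)NC(=O)C2CCN(C(=O)OC(C)(C)C)CC2)cc1` differs from compound 2 by 4-methoxyphenyl in place of 3-chlorophenyl on a sulfonyl sulfur. Going by the values given here, no step between two measured compounds is available to calibrate this change. The expected step is a 1.7-fold higher number from compound 2 to compound 3 (0.23 log units; within the scatter), toward weaker inhibition, though a result within the usual scatter would not surprise. Compound 3 is therefore estimated at 120000 nM, in the range 40000 nM to 400000 nM, with a real chance that this assay again reports only a limit.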

Compound 3, half-maximal inhibitory concentration: 2800 nM
Beside the measured number, compound 3's estimate is 43-fold (1.63 log units) above it; the whole stated range lies above it.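

In this assay, the aryl group on a sulfonyl sulfur proves to be a sensitive position: 4-methoxyphenyl in place of 3-chlorophenyl gives a 25-fold lower number from compound 2 to compound 3 (1.40 log units; beyond the scatter). For the compounds shown here, this is the first step that can be read, and it runs toward stronger inhibition. Compound 1 remains a limit only: the limit of > 100000 nM in this assay, at which 1 of the 3 values shown sits.

This single step changes the group and its place on the ring together, so the contribution of each stays unresolved. Going by these compounds, whether an ethoxy group or an amine on that phenyl ring would keep this gain also remains open.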